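The source may hold more compounds than are shown below. What is called first, only, known or untested is meant among the compounds shown, and "the series" means these compounds.

Measured so far in an ADME assay on Huh-7 cells (Homo sapiens) for cytotoxicity, read by MTT assay, with a stated time of 72 h; a lower number here means that less compound is tolerated, a higher number that more compound is tolerated:
- compound 1 `O=C(NO)c1ccccc1Cl`: compound 1 gives 330000 nM
- compound 2 `O=C(NO)c1ccc(Br)cc1`: compound 2 gives 25000 nM
- compound 3 `Cc1ccc(C(=O)NO)c(Cl)c1`: compound 3 gives 140000 nM

Compound 3 differs from compound 1 by methyl in place of hydrogen on an aromatic carbon; this change gave a 2.4-fold lower number from compound 1 to compound 3 (0.37 log units; beyond the scatter) in this assay. How the core of compound 1 differs from the core of compound 2 is not broken down here; compound 2 simply stands lowest of the three in this assay.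

Compound 4 `Cc1cc(Br)ccc1C(=O)NO`, not yet measured, differs from compound 2 by methyl in place of hydrogen on an aromatic carbon. It is the same kind of change as from compound 1 to compound 3, not the same: here the methyl enters ortho to a hydroxycarbamoyl group and meta to a bromo group, whereas in compound 3 it sits meta to a chloro group and para to a hydroxycarbamoyl group. Resting on that earlier step, a 2.4-fold lower number from compound 1 to compound 3 (0.37 log units; beyond the scatter), a step of similar size is expected, a 2.1-fold lower number from compound 2 to compound 4 (0.32 log units; beyond the scatter). Compound 4 is accordingly estimated at 12000 nM in this assay, expected between 4000 nM and 40000 nM.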

Compound 4, half-maximal cytotoxic concentration: 120000 nM
Compound 4: middle estimate off by 10-fold (1.00 log units), on the low side, outside the stated range (above it).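

In this assay, methyl in place of hydrogen on an aromatic carbon gave a 4.8-fold higher number from compound 2 to compound 4 (0.68 log units; beyond the scatter), and the step does not carry over in direction or size from the earlier core: the same change on two cores in this assay, a 2.4-fold lower number (0.37 log units; beyond the scatter) from compound 1 to compound 3 and a 4.8-fold higher number (0.68 log units; beyond the scatter) from compound 2 to compound 4, 11-fold (1.05 log units) apart, beyond the scatter of two such steps. The outcome of this change in this series therefore depends on the core, on where the methyl sits, or on both, and a step read on one core gives no safe estimate for another. Going by these compounds alone, with only two such steps, and the methyl placed differently in each, these readings cannot be separated, and nothing here shows why the steps differ.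

Left open is whether a methyl ortho to a hydroxycarbamoyl group on the core of compound 1 would follow the step to compound 4. Also open, as far as these compounds go, is whether an ethyl, a methoxy or an amine at that place would move the number the same way.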